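A few compounds are considered here, and "the series" means these few. Any claim that something is new, unique, unknown or untested is made for them only; others in the source may bear on it.

The shared core carries an acylguanidine and a methylsulfonyl group, and the three measured compounds differ in the group on one further aromatic carbon. Compound 1 `CCc1cc(Br)c(S(C)(=O)=O)cc1C(=O)N=C(N)N` carries bromine there; in a functional assay for inhibition of sodium/hydrogen exchanger (Oryctolagus cuniculus) (on this read-out lower numbers stand for stronger inhibition and higher numbers for weaker inhibition), compound 1 gives 41 nM. Compound 2 `Cc1cc(-c2ccc(F)cc2)c(S(C)(=O)=O)cc1C(=O)N=C(N)N` carries a 4-fluorophenyl; in this assay compound 2 gives 36 nM. Compound 3 `Cc1cc(-c2cc(C(F)(F)F)cc(C(F)(F)F)c2)c(S(C)(=O)=O)cc1C(=O)N=C(N)N` carries a phenyl bearing two trifluoromethyl groups; in this assay compound 3 gives 2800 nM. Compound 2 has the lowest of the three numbers, but compound 1 lies within the scatter of it, so these two cannot be ordered; compound 3 lies well beyond the scatter of both.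

Compound 4 `CCOc1cc(C)c(C(=O)N=C(N)N)cc1S(C)(=O)=O` has not yet been measured. It differs from compound 2 in one place: ethoxy in place of 4-fluorophenyl on an aromatic carbon. Among the measured compounds shown here, no measured pair shows this change on its own. Compound 1 shows that a group other than an aryl group at this carbon can give a low number, while compound 3 shows that not every aryl group does. The step from compound 2 is therefore expected to be modest, estimated as a 2.2-fold higher number from compound 2 to compound 4 (0.35 log units; beyond the scatter), toward a higher number but not clearly beyond the scatter. In this assay compound 4 is expected to give 80 nM, with a range from 25 nM to 300 nM.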

Compound 4, half-maximal inhibitory concentration: 19 nM
For compound 4 the middle estimate is 4.2-fold (0.62 log units) above the measured one; measured number outside the range, below it.
By their numbers in this assay, from the lowest: compounds 4, 2 and 1 (each within the scatter of the next, the first and the last beyond it); then compound 3.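

In this assay the exchange of 4-fluorophenyl for ethoxy on this aromatic carbon is a small step, a 1.9-fold lower number from compound 2 to compound 4 (0.28 log units; within the scatter) and so compound 2 and compound 4 cannot be ordered. Among the compounds shown here, this is the first direct read on the position: with the methyl group and the rest of the shared core held constant, a low number does not depend on an aromatic ring at this carbon, and the smaller ethoxy, with no ring and one hydrogen-bond acceptor, serves as well as 4-fluorophenyl within the scatter. The data give no explanation of why two such different groups read alike, and nothing measured on either group bears on the result.

The compounds shown leave open how far this tolerance extends among groups linked through oxygen, for example whether methoxy or a longer chain such as butoxy stays in the same range. They also leave open whether the oxygen itself matters, which a propyl group or an amine on the same carbon would test directly against compound 4.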